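This account rests on a few compounds, and the source may have more. Where it says the series, first, only, none or still open, it means among the compounds named here.

Measured in an ADME assay on T29 cells (Homo sapiens) for cytotoxicity, read by sulforhodamine B assay, with a stated time of 3 days; a higher number here means a weaker inhibitor, a lower number a stronger inhibitor:
compound 1 `O=Cc1cn(Cc2ccc(C(F)(F)F)cc2)c2ccccc12`: > 31600 nM
compound 2 `OCc1cn(Cc2cccc(F)c2)c2ccccc12`: > 31600 nM
compound 3 `OCc1cn(Cc2ccc(Br)cc2)c2ccccc12`: > 31600 nM

Each of these entries is a limit of the assay and not a number. Compound 2 therefore has no exact place on the scale, and its entry of > 31600 nM is only a limit. Compounds 1 and 3 are no different, so the three cannot be put in order. The set as a whole shows (the limit of > 31600 nM in this assay, at which 3 of the 3 values shown sit).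

Compound 4 `O=[N+]([O-])c1cccc(Cn2cc(CO)c3ccccc32)c1` keeps the rest of compound 2 and changes one group: nitro in place of fluoro on an aromatic carbon, meta to a large group (nitro in place of fluoro on an aromatic carbon). Among the measured compounds shown here, no two measured compounds differ in just one place, so no measured step gives a size for this change. The expectation in this assay rests on the limit shared by all three compounds, and no shift beyond the usual scatter is expected. The expected step that the limit leaves unreadable from compound 2 to compound 4 is therefore small. For compound 4 the estimated value is 32000 nM, with an expected range from 12000 nM to 60000 nM.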

Compound 4, half-maximal inhibitory concentration: > 31600 nM
Compound 4: only a limit was reported; the forecaster's own chance of this, stated with the estimate: 75%; the middle value lies beyond the limit too.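

Compound 2 and compound 4 are both recorded only as limits, so the change from fluoro to nitro gives no readable step in this assay. The compounds shown leave open whether any of them differs from the others, because all share one limit: the limit of > 31600 nM in this assay, at which 4 of the 4 values shown sit.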